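The source may report more compounds than this note shows. Statements on the series, on what has been measured and on what is new or still open speak of the compounds shown alone.

Working notes on the series.

Of the compounds shown here, two have been measured in a functional assay on MDA-MB-231 cells (Homo sapiens) for cytotoxicity, read by sulforhodamine B assay, with a stated time of 3 days; on this read-out higher numbers stand for an effect only at larger amounts of compound and lower numbers for an effect already at smaller amounts. Compound 1, `Cc1coc(-c2ccc3c(c2O)CCCC3(C)C)c1C(=O)O`, gives 24.7 uM in this assay. Compound 2, `Cc1coc(-c2ccc3c(c2O)CCCC3)c1C(=O)O`, gives 73.5 uM in this assay. Compound 1 thus stands at the lowest of the two numbers; compound 2 gives a higher number, and the gap between the two lies beyond the usual scatter of this assay.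

The next compound to be measured is compound 3, `COc1c(-c2occ(C)c2C(=O)O)ccc2c1CCCC2(C)C`. Compared with compound 1 it carries methyl in place of hydrogen on an oxygen on an aromatic ring; cut one bond further out, the change reads as hydroxy to methoxy. Going by the values given here, no pair of measured compounds differs in this way, so the size of the step is not anchored by any measured value. The expectation is a moderate move toward higher numbers, the step from compound 1 to compound 3 in this assay being estimated at a 2.0-fold higher number from compound 1 to compound 3 (0.31 log units; beyond the scatter), with a fair chance that it falls within the scatter. For compound 3 the value in this assay is estimated at 50 uM, with a range from 15 uM to 160 uM.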

Compound 3, concentration for half-maximal effect: > 61 uM
Compound 3: only a limit was reported; the forecaster's own chance of this, stated with the estimate: 15%; at least 1.2-fold (0.08 log units) between middle value and limit.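

In this assay compound 3 gives > 61 uM, which is a limit of the assay and not a number. Going by these compounds alone, this is the first reading of any change at this oxygen: methyl in place of hydrogen on an oxygen on an aromatic ring amounts to an at least 2.4-fold higher number from compound 1 to compound 3 (0.39 log units; beyond the scatter), so on this read-out the hydroxy of compound 1 does not tolerate replacement by methoxy without a loss that exceeds the scatter. The step is only a lower bound, and its full size cannot be read from the result: the limit of > 61 uM in this assay, at which 1 of the 3 values shown sits.

At this place the compounds shown hold only hydroxy and methoxy, so it remains open how an ethoxy group, a longer chain on the oxygen or an amine in place of the hydroxy would read in this assay. It also remains open whether hydroxy to methoxy gives a step of similar size on the core of compound 2, and whether any of this extends beyond the single cell line shown here.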